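The source may hold more compounds than are shown below. What is called first, only, known or untested is meant among the compounds shown, and "the series" means these compounds.

Measured in a functional assay on HT-29 cells (Homo sapiens); a higher number here means a weaker inhibitor of growth, a lower number a stronger inhibitor of growth:
- Compound 1 `O=S(=O)(/C=C/c1ccc(Br)cc1)Cc1ccc(Nc2ncnc3ccccc23)cc1`: > 100000 nM
- Compound 2 `O=S(=O)(/C=C/c1ccc(Cl)cc1)Cc1ccc(Nc2ncnc3ccccc23)cc1`: 73000 nM
- Compound 3 `O=S(=O)(/C=C/c1ccc(F)cc1Cl)Cc1ccc(Nc2ncnc3ccccc23)cc1`: 100000 nM

Compound 1 lies at the limit of > 100000 nM in this assay, at which 1 of the 3 values shown sits. This value is a limit and not a number.

Compound 4 `O=S(=O)(/C=C/c1ccc(Br)cc1)Cc1ccc(Nc2ncnc3ccc(Br)cc23)cc1` differs from compound 1 by one change, bromo in place of hydrogen on an aromatic carbon of the shared core: bromo in place of hydrogen on an aromatic carbon.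

Among the compounds with values here, no measured step touches that place. All three steps exchange the group on the double-bonded chain instead. Of these, an at least 1.3-fold lower number from compound 1 to compound 2 (0.13 log units; that floor lies within the scatter), and a 1.4-fold higher number from compound 2 to compound 3 (0.14 log units; within the scatter). The third, a number no higher from compound 1 to compound 3 (the limit leaves the size open), gives no size to work with. These steps offer only indirect guidance, and none of them lies beyond the scatter. A modest step towards a lower number is therefore expected, although its size is uncertain and compound 4 may also remain at the limit.

The expected step is an at least 1.4-fold lower number from compound 1 to compound 4 (0.15 log units; that floor lies within the scatter).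

For compound 4 the estimated value is 70000 nM, with an expected range from 20000 nM to 100000 nM.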

Compound 4, concentration for 50% growth inhibition: 10000 nM
Beside the measured number, compound 4's estimate is 7.0-fold (0.85 log units) above it; the measured number lies below the stated range.
By their numbers in this assay, from the lowest: compound 4; then compounds 2 and 3 (each within the scatter of the next).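

Bromo in place of hydrogen on an aromatic carbon of the shared core gives, in this assay, an at least 10-fold lower number from compound 1 to compound 4 (1.00 log units; beyond the scatter). The earlier steps all exchanged the group on the double-bonded chain and either stayed within the scatter or gave no readable size, so this position, meta to a fused ring and para to a fused ring, is the only place shown where a change lies beyond the scatter. Compound 1 gives only a limit and not a number, so the full size of this step stays unknown: the limit of > 100000 nM in this assay, at which 1 of the 4 values shown sits.

Going by these compounds, it remains open whether chloro, methoxy or an amine at this position would give a similar step. On these data alone, it is also open whether bromo here would act alike alongside the 4-chlorophenyl group of compound 2 or the 2-chloro-4-fluorophenyl group of compound 3.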